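Extending a Hydroxyphenyl Group: Expected Cytotoxicity Outcome

The source may report more compounds than this note shows. Statements on the series, on what has been measured and on what is new or still open speak of the compounds shown alone.

Of the compounds shown here, three built on one shared core have been tested in a functional assay on MKN-45 cells (Homo sapiens) for cytotoxicity, read by MTT assay, with a stated time of 72 h; a higher number here means a weaker inhibitor, a lower number a stronger inhibitor. Compound 1 `CN(C)CCn1cnnc1-c1cc(Oc2ccc(NC(=O)N/N=C/c3ccc(F)cc3F)cc2F)ccn1` gives 810 nM. Compound 2 `CN(C)CCn1cnnc1-c1cc(Oc2ccc(NC(=O)N/N=C/c3cccc(Cl)c3Cl)cc2F)ccn1` gives 51 nM. Compound 3 `CN(C)CCn1cnnc1-c1cc(Oc2ccc(NC(=O)N/N=C/c3ccc(O)cc3)cc2F)ccn1` gives 820 nM. Compound 3 and compound 1 sit within the scatter of each other, as a 1.0-fold higher number from compound 1 to compound 3 (0.01 log units; within the scatter) shows, while compound 3 stands well apart from compound 2, since a 16-fold higher number from compound 2 to compound 3 (1.21 log units; beyond the scatter).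

Compound 4 `COc1ccc(/C=N/NC(=O)Nc2ccc(Oc3ccnc(-c4nncn4CCN(C)C)c3)c(F)c2)cc1O` differs from compound 3 in one place: 3-hydroxy-4-methoxyphenyl in place of 4-hydroxyphenyl on a carbon with a double bond to nitrogen. Going by the values given here, no measured step adds a methoxy group to this ring; the measured steps exchange the whole ring. Of these, a 16-fold lower number from compound 1 to compound 2 (1.20 log units; beyond the scatter) was large, whereas a 1.0-fold higher number from compound 1 to compound 3 (0.01 log units; within the scatter) stayed within the scatter. The change to compound 4 keeps the hydroxy group and adds a methoxy group, so a small step, not beyond the scatter in this assay, is expected: a 1.2-fold lower number from compound 3 to compound 4 (0.07 log units; within the scatter). Compound 4 is therefore estimated at 700 nM, with a range from 250 nM to 2000 nM.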

Compound 4, half-maximal inhibitory concentration: 2510 nM
The estimate for compound 4 lay 3.6-fold (0.55 log units) below the measured number; the measured number lies above the stated range.
By their numbers in this assay, from the lowest: compound 2; then compounds 1 and 3 (each within the scatter of the next); then compound 4.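

In this assay this position responds even to a change that keeps a hydroxy group on the ring: 3-hydroxy-4-methoxyphenyl in place of 4-hydroxyphenyl gives a 3.1-fold higher number from compound 3 to compound 4 (0.49 log units; beyond the scatter) as a modest loss, whereas 4-hydroxyphenyl and 2,4-difluorophenyl could not be told apart. The new ring gives a 3.1-fold higher number from compound 1 to compound 4 (0.49 log units; beyond the scatter) against 2,4-difluorophenyl and a 49-fold higher number from compound 2 to compound 4 (1.69 log units; beyond the scatter) against 2,3-dichlorophenyl, which makes compound 4 the weakest of the four, with all its steps beyond the scatter. Nothing measured here accounts for these shifts.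

The compounds shown cannot separate the effect of the methoxy group from that of the new place of the hydroxy group on the ring. As far as these compounds go, how a phenyl ring carrying an amine or a carboxylic acid would fare at this position also remains open.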